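The source may report more compounds than this note shows. Statements on the series, on what has been measured and on what is new or still open speak of the compounds shown alone.

Series with the shared core of compound 1 `CSc1cnc2ccccc2c1SCC#CCO` varied at the end of the chain. In a functional assay on SW707 cells (Homo sapiens) for antiproliferative activity, with a stated time of 72 h (on this read-out higher numbers stand for weaker inhibition and lower numbers for stronger inhibition), compound 1 gives 34.9 ug/mL. Among the compounds with values here, compound 2 `CSc1cnc2ccccc2c1SCC#CCCl` gives 3.7 ug/mL, and the step of a 9.4-fold lower number from compound 1 to compound 2 (0.97 log units; beyond the scatter) is the only single change in this set. Compound 3 `CSc1cnc2ccccc2c1[Se]CC#CCOC(=O)/C=C/c1ccccc1` gives 4.7 ug/mL; it stands second highest of the three numbers, with compound 2 nearest, the two values lying within the scatter of each other, and compound 1 furthest, beyond the scatter. No step is shown for either pair involving compound 3, so only the two values themselves speak.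

Compound 4 `CSc1cnc2ccccc2c1[Se]CC#CCOC(=O)c1ccc(C(=O)O)cc1` differs from compound 3 by 4-carboxyphenyl in place of 2-phenylethenyl on a carbonyl carbon. Within the data shown here, none of the measured steps touches this part of the molecule: the change from compound 1 to compound 2 concerns the chain end, not the ester. Among the measured compounds shown here, there is therefore no measured step to scale from, and the expectation is a number close to that of compound 3, with a wide range. The step of a 1.5-fold higher number from compound 3 to compound 4 (0.17 log units; within the scatter) is expected to stay near or within the scatter, in either direction. Compound 4 is estimated at 7 ug/mL, between 2.5 ug/mL and 25 ug/mL.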

Compound 4, concentration for 50% inhibition: 3.7 ug/mL
Estimate against measurement, compound 4: 1.9-fold (0.28 log units) above; the range from low to high includes it.
By their numbers in this assay, from the lowest: compounds 2, 4 and 3 (each within the scatter of the next); then compound 1.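

In this assay, within the data shown here, 4-carboxyphenyl in place of 2-phenylethenyl on a carbonyl carbon gives a 1.3-fold lower number from compound 3 to compound 4 (0.10 log units; within the scatter), the first single change that lies on the ester rather than at the chain end. At this place, the two groups cannot be told apart on this read-out, even though 4-carboxyphenyl carries a hydrogen-bond donor and a hydrogen-bond acceptor that 2-phenylethenyl lacks. No measurement at hand offers an explanation for this result.

From the compounds shown here alone, whether this insensitivity holds for a simple methyl, a longer saturated chain or an amine-bearing phenyl on the same carbonyl carbon remains open. Selenium and sulfur in the chain are also not separated, as no pair shown differs in that one place alone.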